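A Methyl Ester Variant of Compound 2

The compounds below may be only part of what the source reports. "The series", "measured", "known", "first", "only" and "open" are said of these compounds alone.

For the measured compounds named here, compound 2 `N[C@@H](CSNC(=O)[C@@H](CCC(F)(F)F)N(Cc1ccc(-c2ncon2)cc1F)S(=O)(=O)c1ccc(Cl)cc1)C(=O)O` carries the only plain number here: in a physicochemical assay for pharmacokinetics, at pH 4, tested at 100 ug/mL (on this read-out higher numbers stand for a longer-lived compound and lower numbers for a shorter-lived compound), compound 2 gives 418 h. Compound 1 `NCCSNC(=O)[C@@H](CCC(F)(F)F)N(Cc1ccc(-c2ncon2)cc1F)S(=O)(=O)c1ccc(Cl)cc1` gives only a limit of this assay, > 500 h. Compound 3 `COC(=O)[C@@H](N)CSNC(=O)[C@@H](CCC(F)(F)F)N(Cc1ccc(-c2ncon2)cc1F)S(=O)(=O)c1ccc(Cl)cc1` differs from compound 2 by methyl in place of hydrogen on an oxygen next to a carbonyl group. Going by the values given here, no measured step touches that oxygen; the single measured step, an at least 1.1-fold lower number from compound 1 to compound 2 (0.07 log units; that floor lies within the scatter), alters another place and stays within the scatter, one end being (the limit of > 500 h in this assay, at which 1 of the 2 values shown sits). Compound 3 is therefore expected to show a 1.0-fold higher number from compound 2 to compound 3 (0.01 log units; within the scatter), nothing beyond the scatter. Compound 3 is estimated at 430 h, between 200 h and 900 h.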

Compound 3, half-life: 185 h
Compound 3: the middle estimate sits 2.3-fold (0.37 log units) above what was measured, and the stated range ends above it.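

In this assay, methyl on this oxygen next to a carbonyl group makes a real difference: a 2.3-fold lower number from compound 2 to compound 3 (0.35 log units; beyond the scatter). Methoxycarbonyl in place of hydrogen on the chain carbon also gives an at least 2.7-fold lower number from compound 1 to compound 3 (0.43 log units; beyond the scatter), while the floor of the earlier step to carboxy stayed within the scatter. Compound 1 gives only a limit, so this second step is a floor: the limit of > 500 h in this assay, at which 1 of the 3 values shown sits.

As far as these compounds go, it remains open whether ethyl, a longer chain on this oxygen, would follow methyl. From the compounds shown here alone, it also remains open how a primary amide in place of the carboxy group would read.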